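A few compounds are considered here, and "the series" means these few. Any claim that something is new, unique, unknown or untested is made for them only; others in the source may bear on it.

Measured so far:
compound 1, `CNCc1cc(-c2cccnc2F)n(S(=O)(=O)c2ccccc2)c1`: 99%
compound 2, `CNCc1cc(-c2cccnc2F)n(S(=O)(=O)c2ccco2)c1`: 74%

In a functional assay on the whole organism (strain Jcl:SD) for inhibition, with Rattus norvegicus as the target, with stated times of 3 min and 3 h, at a dose of 1 mg/kg by the intravenous route (on this read-out higher numbers stand for more inhibition at the one dose given (going by the name of the read-out) and lower numbers for less inhibition), compound 1 gives 99%, and compound 2 gives 74%. Going by the values given here, compound 2 is the lower of the two numbers; compound 1 is its only neighbour, separated by the step of a number 25 percentage points lower from compound 1 to compound 2 (beyond the scatter).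

Compound 3, `CNCc1cc(-c2cccnc2F)n(S(=O)(=O)c2cccnc2)c1`, is not yet measured. It differs from compound 2 by pyridin-3-yl in place of furan-2-yl on a sulfonyl sulfur. Among the compounds with values here, the only measured step that bears on this is a number 25 percentage points lower from compound 1 to compound 2 (beyond the scatter), a modest fall when a five-membered aromatic ring replaced a six-membered one on the same sulfonyl sulfur. Since a six-membered aromatic ring now returns, the step of a number 12 percentage points higher from compound 2 to compound 3 (beyond the scatter) is expected to run upward, though no pyridin-3-yl has been measured here, so the expectation is loose. Compound 3 is estimated at 86%, within 62% to 99%.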

Compound 3, a percentage reported as inhibition, in the whole organism at one dose (the size of the read-out at that dose, not a potency): 96%
Compound 3: middle estimate off by 10 percentage points, on the low side; the measured number falls inside the stated range.
By their numbers in this assay, from the lowest: compound 2; then compounds 3 and 1 (each within the scatter of the next).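

In this assay the change from furan-2-yl to pyridin-3-yl on the sulfonyl sulfur reads a number 22 percentage points higher from compound 2 to compound 3 (beyond the scatter), while the change from phenyl to pyridin-3-yl reads a number 3 percentage points lower from compound 1 to compound 3 (within the scatter). A hetero atom in the ring at this place therefore does not by itself bring the fall seen with furan-2-yl, and of these three compounds only the five-membered ring stands apart. No available data bear on the reason for this difference.

Thiophen-2-yl would test whether the fall extends to another five-membered aromatic ring. Open too, from the compounds shown here alone, is how a methyl group or a piperidine ring on the sulfonyl sulfur would read.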